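Adding a Third Methoxy Group to Compound 3

A few compounds are considered here, and "the series" means these few. Any claim that something is new, unique, unknown or untested is made for them only; others in the source may bear on it.

Compound 1 `O=C(NCc1cn(Cc2ccc(F)cc2)nn1)c1cn(-c2ccccc2)nc1-c1ccc(F)cc1`: in a functional assay on HeLa cells (Homo sapiens) for antiproliferative activity, read by sulforhodamine B assay, with a stated time of 48 h (on this read-out higher numbers stand for weaker inhibition of growth and lower numbers for stronger inhibition of growth), compound 1 gives 1200 nM.
Compound 2 `O=C(NCc1cn(Cc2ccc(Cl)cc2)nn1)c1cn(-c2ccccc2)nc1-c1ccc(F)cc1`: compound 2 gives 210 nM.
Compound 3 `COc1cc(Cn2cc(CNC(=O)c3cn(-c4ccccc4)nc3-c3ccc(F)cc3)nn2)cc(OC)c1`: compound 3 gives 360 nM.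

Compound 3 stands second highest of the three numbers: it lies within the scatter of compound 2, while the step of a 3.3-fold lower number from compound 1 to compound 3 (0.52 log units; beyond the scatter) is beyond it. Compound 4 `COc1cc(Cn2cc(CNC(=O)c3cn(-c4ccccc4)nc3-c3ccc(F)cc3)nn2)cc(OC)c1OC` differs from compound 3 by methoxy in place of hydrogen on an aromatic carbon. Among the measured compounds shown here, no measured step touches this change. The steps of a 5.7-fold lower number from compound 1 to compound 2 (0.76 log units; beyond the scatter) and a 3.3-fold lower number from compound 1 to compound 3 (0.52 log units; beyond the scatter) replace the whole aryl group rather than add to it, and a 1.7-fold higher number from compound 2 to compound 3 (0.23 log units; within the scatter) stays within the scatter. Nothing here points to a step beyond the scatter in this assay in either direction. Compound 4 is therefore expected to give 300 nM, between 100 nM and 900 nM, an estimated 1.2-fold lower number from compound 3 to compound 4 (0.08 log units; within the scatter).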

Compound 4, concentration for 50% growth inhibition: 2100 nM
Compound 4: the middle estimate sits 7.0-fold (0.85 log units) below what was measured, and the stated range ends below it.
By their numbers in this assay, from the lowest: compounds 2 and 3 (each within the scatter of the next); then compounds 1 and 4 (each within the scatter of the next).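

In this assay, methoxy in place of hydrogen on the aromatic carbon ortho to two methoxy groups weakens growth inhibition (a 5.8-fold higher number from compound 3 to compound 4 (0.77 log units; beyond the scatter)), so this carbon of the 3,5-dimethoxyphenyl group does not accept the addition neutrally. The 3,4,5-trimethoxyphenyl group also falls well short of 4-chlorophenyl (a 10-fold higher number from compound 2 to compound 4 (1.00 log units; beyond the scatter)), yet cannot be told apart from 4-fluorophenyl (a 1.8-fold higher number from compound 1 to compound 4 (0.24 log units; within the scatter)). Nothing available explains this loss. On these data alone, whether it is particular to methoxy stays open, as a hydroxy group, fluorine or ethoxy on that carbon could show. Also open, as far as these compounds go, is whether methoxy there would act the same without the two flanking methoxy groups.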